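This account rests on a few compounds, and the source may have more. Where it says the series, first, only, none or still open, it means among the compounds named here.

Measured so far:
- Compound 1 `O=C(Nc1ccc(-c2ccc[nH]2)cc1)[C@H]1CCCN(Cc2ccc(F)c(F)c2)C1` with 190 nM
- Compound 2 `O=C(Nc1ccc(-c2ccc[nH]2)cc1F)[C@H]1CCCN(Cc2ccc(F)c(F)c2)C1` with 130 nM

In a functional assay on A-375 cells (Homo sapiens) for antiproliferative activity (a higher number here means a weaker inhibitor, a lower number a stronger inhibitor), compound 1 gives 190 nM and compound 2 gives 130 nM so these two numbers lie within the usual scatter of each other. Going by the values given here, compound 1 therefore stands level with the only other measured compound, and this gives a very narrow view of the series.

Compound 3 `Cc1cc(NC(=O)[C@H]2CCCN(Cc3ccc(F)c(F)c3)C2)ccc1-c1ccc[nH]1` has not yet been measured. Its difference from compound 1 is methyl in place of hydrogen on an aromatic carbon and this is a small edit, with methyl in place of hydrogen on an aromatic carbon.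

Among the compounds with values here, one measured step bears on it. The fluoro swap shows a 1.5-fold lower number from compound 1 to compound 2 (0.16 log units; within the scatter) as its size, and that stays within the scatter. It is only a loose guide, since fluoro is a different group from methyl and no methyl swap has been measured. A small swap on this ring has so far left this assay unmoved, so no shift beyond the scatter is expected in either direction.

The estimate amounts to a 1.1-fold higher number from compound 1 to compound 3 (0.02 log units; within the scatter) as the expected step. For compound 3 the expected value is 200 nM with an estimated range from 80 nM to 500 nM around it.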

Compound 3, half-maximal inhibitory concentration: 730 nM
For compound 3 the middle estimate is 3.7-fold (0.56 log units) below the measured one; measured number above the stated range.
By their numbers in this assay, from the lowest: compounds 2 and 1 (each within the scatter of the next); then compound 3.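

In this assay the methyl on the six-membered aromatic ring, ortho to a 1H-pyrrol-2-yl group, gives a 3.8-fold higher number from compound 1 to compound 3 (0.58 log units; beyond the scatter) and this is the first step in the series shown to pass beyond the scatter. The earlier swap on this ring, a 1.5-fold lower number from compound 1 to compound 2 (0.16 log units; within the scatter) stayed within the scatter, so that result gave no sign that a small change here could matter. The new step shows that this ring is not indifferent to every small addition: one extra carbon at this position is enough for a modest rise in the number, which means a weaker inhibitor.

The fluoro of compound 2 and the methyl of compound 3 differ both as groups and in where they sit on the ring, so these two steps cannot separate the effect of the group from the effect of its place. On these data alone, it remains open whether a chlorine atom or a methoxy group ortho to the 1H-pyrrol-2-yl group would raise the number as methyl does, and how methyl would behave elsewhere on the ring. Nothing measured here gives a reason for the rise.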